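A few compounds are considered here, and "the series" means these few. Any claim that something is new, unique, unknown or untested is made for them only; others in the source may bear on it.

Measured in a physicochemical assay, with a stated time of 6 min; a higher number here means a weaker inhibitor, a lower number a stronger inhibitor:
- compound 1 `O=C(Nc1ccc(F)cc1)Nc1nc(-c2cc3ccccc3o2)cs1`: 1130 nM
- compound 2 `O=C(Nc1ccc([N+](=O)[O-])cc1)Nc1nc(-c2cc3ccccc3o2)cs1`: 19300 nM

Of the two, compound 2 stands highest at 19300 nM, which makes it the weaker inhibitor. The next step leads to compound 3 `O=C(Nc1cccc(F)c1)Nc1nc(-c2cc3ccccc3o2)cs1`, with 3-fluorophenyl in place of 4-nitrophenyl on an amide-type nitrogen. Among the compounds with values here, only one measured step bears on this change: a 17-fold higher number from compound 1 to compound 2 (1.23 log units; beyond the scatter). That step put nitro in place of fluoro, and compound 3 again carries a fluoro group, so the step is read here in reverse. Within the data shown here, no measured compound tests the 3-fluorophenyl group itself, which leaves the estimate wide. In this assay a large step towards a lower number is expected: a 13-fold lower number from compound 2 to compound 3 (1.11 log units; beyond the scatter). For compound 3 the estimated value is 1500 nM, with an expected range of 500 nM to 5000 nM.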

Compound 3, half-maximal inhibitory concentration: 4520 nM
Compound 3: the middle estimate sits 3.0-fold (0.48 log units) below what was measured, and the stated range covers the measured number.
By their numbers in this assay, from the lowest: compound 1; then compound 3; then compound 2.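

In this assay, the two fluoro compounds do not read alike: 3-fluorophenyl in place of 4-fluorophenyl on the amide-type nitrogen gives a 4.0-fold higher number from compound 1 to compound 3 (0.60 log units; beyond the scatter) and so shows that the placing of the fluoro group counts at this position, not only its presence. Exchanging 4-nitrophenyl for 3-fluorophenyl gives a 4.3-fold lower number from compound 2 to compound 3 (0.63 log units; beyond the scatter) and closes only part of the gap opened by the nitro group, leaving the 4-fluorophenyl group with the lowest number of the three. No measurement at hand accounts for either difference.

Still open, going by these compounds, is how 3-nitrophenyl would compare with 4-nitrophenyl, and so whether the order seen for the fluoro pair holds for another group. Also open, on these data alone, is how an aminophenyl or methoxyphenyl group would read at this nitrogen.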